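Biaryl lactone series: replacing the dichlorophenyl arm

A few compounds are considered here, and "the series" means these few. Any claim that something is new, unique, unknown or untested is made for them only; others in the source may bear on it.

Compound 1 `O=C1C[C@H](O)C[C@@H](/C=C/c2c(Cl)cc(Cl)cc2-c2cc(Cl)cc(Cl)c2)O1` gives the lowest of the three measured numbers in an assay for inhibition of 3-hydroxy-3-methylglutaryl-coenzyme A reductase (Rattus norvegicus) (on this read-out lower numbers stand for stronger inhibition and higher numbers for weaker inhibition), at 37 nM. Compound 3 `O=C1C[C@H](O)CC(CCc2c(Cl)cc(Cl)cc2-c2ccccc2)O1` gives 100 nM in this assay, beyond the scatter above compound 1, and compound 2 `O=C1C[C@H](O)CC(CCc2ccccc2-c2ccccc2)O1` gives 44000 nM, far above both. Compound 4 `O=C1C[C@H](O)C[C@@H](/C=C/c2c(Cl)cc(Cl)cc2CCc2ccccc2)O1` is not yet measured; relative to compound 1 it carries phenethyl in place of 3,5-dichlorophenyl on an aromatic carbon. The two chloro groups on the first ring are kept, and a number like that of compound 2, 44000 nM, is not expected; yet compound 3, at 100 nM, shows that a second ring without chloro groups already raised the number beyond the scatter. The step of an 8.1-fold higher number from compound 1 to compound 4 (0.91 log units; beyond the scatter) is therefore expected to be a weakening beyond the scatter. Compound 4 is estimated at 300 nM, within the range 60 nM to 1500 nM.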

Compound 4, half-maximal inhibitory concentration: 430 nM
Compound 4: middle estimate off by 1.4-fold (0.16 log units), on the low side, and the stated range covers the measured number.
By their numbers in this assay, from the lowest: compound 1; then compound 3; then compound 4; then compound 2.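

In this assay, phenethyl in place of 3,5-dichlorophenyl on an aromatic carbon gives a 12-fold higher number from compound 1 to compound 4 (1.07 log units; beyond the scatter), the first single-place step read at this position. The arm is therefore not interchangeable here: the heavy-atom count and the aromatic ring stay the same, and the two chloro groups on the core are kept, yet the number rises well beyond the scatter. No measured property on hand accounts for this step.

Still open, on these data alone, is whether chloro groups on the phenethyl ring would recover any of this loss. Also open, as far as these compounds go, is how an amine, a carboxylic acid or a longer chain at this position would read.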